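Replacing the pyrazole group of compound 2

The compounds below may be only part of what the source reports. "The series", "measured", "known", "first", "only" and "open" are said of these compounds alone.

Measured in an ADME assay on microsomes from liver (Homo sapiens) for metabolic stability; a higher number here means faster removal of the compound, a lower number slower removal:
- compound 1 `Cc1ccc2[nH]c(C(=O)N[C@H]3CN(S(=O)(=O)c4ccccc4)C[C@@H]3C(=O)NC[C@@H]3CCCN3C)cc2c1`: 31 mL.min-1.g-1
- compound 2 `O=C(N[C@H]1CN(S(=O)(=O)c2ccccc2)C[C@@H]1C(=O)N[C@H]1CCCNC1)c1cc(C2CC2)n[nH]1`: < 3 mL.min-1.g-1 (a limit, not a number)

Only compound 1 has a numerical value in this assay, at 31 mL.min-1.g-1. Compound 2 stands at a limit of the assay, < 3 mL.min-1.g-1 (the limit of < 3 mL.min-1.g-1 in this assay, at which 1 of the 2 values shown sits).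

Compound 3 `O=C(N[C@H]1CN(S(=O)(=O)c2ccccc2)C[C@@H]1C(=O)N[C@H]1CCCNC1)c1nnc(-c2ccc(F)cc2)s1` keeps the core and side chain of compound 2 and differs in one place, on a carbonyl carbon: a group of 12 heavy atoms (8 carbon, 2 nitrogen, 1 fluorine, 1 sulfur; one five-membered aromatic ring with 3 hetero atoms, one six-membered aromatic ring of carbon only) in place of a group of 8 heavy atoms (6 carbon, 2 nitrogen; one three-membered non-aromatic ring of carbon only, one five-membered aromatic ring with 2 hetero atoms), on a carbonyl carbon.

Among the compounds with values here, no measured pair shows the effect of such a change, so the expected size of the step is loosely bounded. With compound 2 at < 3 mL.min-1.g-1, any measurable change in this assay can appear only as a rise. A moderate rise, beyond the scatter, is expected, to a value short of that of compound 1 at 31 mL.min-1.g-1. The estimate is an at least 3.0-fold higher number from compound 2 to compound 3 (0.47 log units; beyond the scatter). For compound 3 the expected value is 9 mL.min-1.g-1, with an estimated range of 3 mL.min-1.g-1 to 30 mL.min-1.g-1.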

Compound 3, intrinsic clearance in microsomes: 8.8 mL.min-1.g-1
Beside the measured number, compound 3's estimate is 1.0-fold (0.01 log units) above it; the measured number falls inside the stated range.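

Exchanging 3-cyclopropyl-1H-pyrazol-5-yl on the carbonyl carbon for the group of compound 3, which has a five-membered aromatic ring with 3 hetero atoms and a six-membered aromatic ring of carbon only, gives in this assay an at least 2.9-fold higher number from compound 2 to compound 3 (0.46 log units; beyond the scatter). This is the only pair shown that differs in one place, so it is the first direct sign that this position can move the read-out while the core and side chain stay fixed. Compound 2 gives only a limit, so the step has a lower bound and no exact size: the limit of < 3 mL.min-1.g-1 in this assay, at which 1 of the 3 values shown sits.

The entering group differs from the one it replaces in both rings and in its fluorine, so the pair leaves open which of these parts goes with the rise, and what a plain phenyl, an amine or a carboxylic acid on the six-membered ring would give. Going by these compounds, compound 1 differs from compound 3 in more than one place, so the effect of the side chain on removal in this assay also stays open.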